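Dimethyl to Difluoro on the Anilide: Expected Cytotoxicity

The source may report more compounds than this note shows. Statements on the series, on what has been measured and on what is new or still open speak of the compounds shown alone.

Compound 1, `COc1ccc2nc(C(F)(F)F)cc(OCC(=O)Nc3cc(C)cc(C)c3)c2c1`, in a toxicity assay on HepG2 cells (Homo sapiens) for inhibition, read by CellTiter-Glo, with a stated time of 48 h (a lower number here means a stronger inhibitor, a higher number a weaker inhibitor), gives > 100000 nM, a limit of the assay. Compound 2, `COc1ccc2nc(C)cc(OCC(=O)Nc3c(C)cccc3C)c2c1`, gives > 100000 nM, also a limit. Compound 3, `COc1ccc2nc(C)cc(OCC(=O)Nc3cc(C)c(OC)c(C)c3)c2c1`, gives 7940 nM.

Going by the values given here, compound 2 thus sits at the limit of > 100000 nM in this assay, at which 2 of the 3 values shown sit; only a limit is known for it, and compound 3 is the one compound with a number. Compound 4, `COc1ccc2nc(C)cc(OCC(=O)Nc3cc(F)cc(F)c3)c2c1`, differs from compound 2 in one place: 3,5-difluorophenyl in place of 2,6-dimethylphenyl on an amide-type nitrogen. Among the compounds with values here, no step between measured compounds follows this change, so nothing measured sizes it. The step of an at least 1.6-fold lower number from compound 2 to compound 4 (0.22 log units; that floor lies within the scatter) is expected to be none beyond the scatter. Compound 4 is expected to give 60000 nM, within 15000 nM to 200000 nM, with a fair chance that only a limit is reported again.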

Compound 4, half-maximal inhibitory concentration: > 100000 nM
Compound 4: no number, only a limit; the forecaster's own chance of this, stated with the estimate: 55%; middle value at least 1.6-fold (0.22 log units) away from the limit.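

In this assay compound 4 gives > 100000 nM, a limit of the assay. Going by these compounds alone, compound 2 gives > 100000 nM, also a limit, so no step between compound 2 and compound 4 can be read. The compounds shown leave open whether 3,5-difluorophenyl in place of 2,6-dimethylphenyl changes the value at all.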